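Methoxy Addition on a Benzopyran Series

The source may hold more compounds than are shown below. What is called first, only, known or untested is meant among the compounds shown, and "the series" means these compounds.

Of the compounds shown here, three have been measured in a functional assay on T47D cells (Homo sapiens) for activation; on this read-out higher numbers stand for an effect only at larger amounts of compound and lower numbers for an effect already at smaller amounts. Compound 3 `COc1ccc2c(c1)OC(N)=C(C#N)C2c1cccnc1` gives 170000000 nM. Compound 2 `COc1cncc(C2C(C#N)=C(N)Oc3cc(OC)ccc32)c1` gives 47000000 nM. The change from compound 3 to compound 2 is methoxy in place of hydrogen on an aromatic carbon and yields a 3.6-fold lower number from compound 3 to compound 2 (0.56 log units; beyond the scatter). Compound 1 `CCNc1ccc2c(c1)OC(N)=C(C#N)C2c1cccc(OC)c1` gives 110000000 nM; the difference between the core of compound 1 and that of compound 3 is not broken down here.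

Compound 4 `CCNc1ccc2c(c1)OC(N)=C(C#N)C2c1cc(OC)cc(OC)c1` is not yet measured in this assay. It differs from compound 1 by methoxy in place of hydrogen on an aromatic carbon. For the measured compounds named here, this is the same kind of change as the one from compound 3 to compound 2, yet the place is not the same: there the methoxy enters a six-membered aromatic ring with one nitrogen, two atoms from the ring nitrogen, whereas here it enters a six-membered aromatic ring of carbon only, meta to a methoxy group. Because compound 2 shows a 3.6-fold lower number from compound 3 to compound 2 (0.56 log units; beyond the scatter), compound 4 is expected to show a similar step, a 2.4-fold lower number from compound 1 to compound 4 (0.39 log units; beyond the scatter). Compound 4 is therefore estimated at 45000000 nM, expected to lie between 18000000 nM and 120000000 nM.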

Compound 4, half-maximal effective concentration: 61700000 nM
The estimate for compound 4 lay 1.4-fold (0.14 log units) below the measured number; the measured number falls inside the stated range.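

In this assay, methoxy in place of hydrogen on an aromatic carbon of the six-membered aromatic ring of carbon only gives a 1.8-fold lower number from compound 1 to compound 4 (0.25 log units; within the scatter), so this step alone cannot be told apart from the spread of repeated measurements. Set beside the earlier step, it does not differ from it by more than such measurements allow: the same change on two cores in this assay, a 3.6-fold lower number (0.56 log units; beyond the scatter) from compound 3 to compound 2 and a 1.8-fold lower number (0.25 log units; within the scatter) from compound 1 to compound 4, 2.0-fold (0.31 log units) apart, within the scatter of two such steps

This agrees with the change carrying over from one core to the other, but it does not establish that it does: only the earlier step lies beyond the scatter, the methoxy enters a different kind of ring in each case, and two pairs support no general rule for the series.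

The compounds shown leave open whether another group at this place, such as an amine, a carboxylic acid or a longer chain like butoxy, would give a step beyond the scatter on the core of compound 1. They also leave open how the methoxy step would behave on any further core.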